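The source may hold more compounds than are shown below. What is called first, only, known or untested is meant among the compounds shown, and "the series" means these compounds.

- Compound 1 `CN(C)C(=O)c1cc2cnc(Nc3ccc(NC(=O)C4(C(=O)Nc5cccc(Cl)c5)CC4)cc3)nc2n1C1CCCC1`: 16.2%
- Compound 2 `CN(C)C(=O)c1cc2cnc(Nc3ccc(NC(=O)C4(C(=O)Nc5cccc(Br)c5)CC4)cc3)nc2n1C1CCCC1`: 13.9%

Among the measured compounds shown here, in a functional assay on SiHa cells (Homo sapiens) for inhibition, read by CCK-8 assay, with a stated time of 72 h, tested at 1 uM (on this read-out higher numbers stand for more inhibition of growth at the one concentration tested and lower numbers for less inhibition of growth), compound 2 gives 13.9%, within the scatter of compound 1, the only other measured compound. Compound 3 `CN(C)C(=O)c1cc2cnc(Nc3ccc(NC(=O)C4(C(=O)Nc5ccc(O)cc5)CC4)cc3)nc2n1C1CCCC1` carries 4-hydroxyphenyl in place of 3-bromophenyl on an amide-type nitrogen. For the measured compounds named here, the one measured step, a number 2.3 percentage points lower from compound 1 to compound 2 (within the scatter), exchanges chloro for bromo on an aromatic carbon. Going by the values given here, no measured compound carries 4-hydroxyphenyl, so this small step is only a weak guide, and no clear direction can be drawn from it. The expected change is a number 0.9 percentage points lower from compound 2 to compound 3 (within the scatter), with no shift beyond the scatter anticipated. For compound 3 the estimated value is 13%, within an expected range of 3% to 30%.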

Compound 3, percent growth inhibition at one concentration: 69.5%
Beside the measured number, compound 3's estimate is 56.5 percentage points below it, outside the stated range (above it).
By their numbers in this assay, from the lowest: compounds 2 and 1 (each within the scatter of the next); then compound 3.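

In this assay the group on the amide-type nitrogen proves far more sensitive than the exchange of one halogen for another hinted: 4-hydroxyphenyl in place of 3-bromophenyl gives a number 55.6 percentage points higher from compound 2 to compound 3 (beyond the scatter) and 4-hydroxyphenyl in place of 3-chlorophenyl gives a number 53.3 percentage points higher from compound 1 to compound 3 (beyond the scatter) with the rest of the molecule unchanged. The entering group brings a hydrogen-bond donor and acceptor that the halogen-bearing groups lack, but the substituent's place on the ring changes too. Nothing available gives a cause for this rise. As far as these compounds go, whether the hydroxy group itself or its ring place matters remains open; 3-hydroxyphenyl and 4-methoxyphenyl would help separate the two.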